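The source may hold more compounds than are shown below. What is called first, only, known or untested is meant among the compounds shown, and "the series" means these compounds.

Compound 1 `CNNc1nnc(-c2ccccc2C)s1` gives > 100 mg/kg in a functional assay on the whole organism with Mus musculus as the target, with a stated time of 1 h (a higher number here means that more compound is needed for the effect, a lower number that less compound is needed), a limit of the assay.
Compound 2 `Cc1ccccc1-c1nnc(NNC2CCCC2)s1` gives > 100 mg/kg in this assay, also a limit.

Compound 2 therefore stands only at a limit, one of the two values that sit there (the limit of > 100 mg/kg in this assay, at which 2 of the 2 values shown sit). For the measured compounds named here, the one measured step, a step that the two limits leave unreadable from compound 1 to compound 2, lies between two limits and its size cannot be read. Compound 3 `Clc1ccccc1-c1nnc(NNC2CCCC2)s1` carries chloro in place of methyl on an aromatic carbon. Going by the values given here, no measured step involves this change, so nothing among the measured values speaks for or against a shift beyond the scatter. Compound 3 is expected to remain at the limit, with an estimate of 150 mg/kg spanning 50 mg/kg to 450 mg/kg. The expected step is a step that the limit leaves unreadable from compound 2 to compound 3.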

Compound 3, dose for half-maximal effect: > 100 mg/kg
Compound 3 gave a limit, no number (the forecaster's own chance of this, stated with the estimate: 80%); the middle value lies beyond the limit too.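

For the compounds shown here, compound 2 and compound 3 both sit at a limit, so no step between them can be read. The compounds shown leave open whether chloro or methyl makes any difference in this assay, and how the three compounds rank there: the limit of > 100 mg/kg in this assay, at which 3 of the 3 values shown sit.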